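The source may hold more compounds than are shown below. What is called first, only, known or untested is meant among the compounds shown, and "the series" means these compounds.

In an ADME assay on microsomes from liver (Homo sapiens) for metabolic stability, read by LC-MS, using NADPH, with stated times of 5 min and 30 min, tested at 1 uM (a higher number here means faster removal of the compound, a lower number slower removal), compound 1 (`Cc1ncc(-c2cnc(NCc3c(F)ccc4c3CCO4)c3cn[nH]c(=O)c23)n1C`) gives 10 mL.min-1.g-1 and compound 2 (`CN(c1ccn(C)n1)c1cnc(NCc2c(F)ccc3c2CCO3)n2cnnc12`) gives 11 mL.min-1.g-1, so the two stand within the scatter of each other. Compound 3 (`CN(c1ccn(C)n1)c1cnc(NCc2c(F)ccc3c2CCO3)c2cn[nH]c(=O)c12`) departs from compound 1 in one place, on an aromatic carbon of the shared core: methyl(1-methyl-1H-pyrazol-3-yl)amino in place of 1,2-dimethyl-1H-imidazol-5-yl on an aromatic carbon. Among the compounds with values here, no pair of measured compounds isolates this change, so only a small move in this assay is expected, with no direction beyond the scatter. The estimated shift is a 1.2-fold higher number from compound 1 to compound 3 (0.08 log units; within the scatter). For compound 3 the expected value is 12 mL.min-1.g-1, with an estimated range of 6 mL.min-1.g-1 to 24 mL.min-1.g-1.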

Compound 3, intrinsic clearance in microsomes: 62 mL.min-1.g-1
Estimate against measurement, compound 3: 5.2-fold (0.71 log units) below; measured number outside the range, above it.
By their numbers in this assay, from the lowest: compounds 1 and 2 (each within the scatter of the next); then compound 3.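

In this assay this position on an aromatic carbon of the shared core proves sensitive to the group it carries: methyl(1-methyl-1H-pyrazol-3-yl)amino in place of 1,2-dimethyl-1H-imidazol-5-yl gives a 6.2-fold higher number from compound 1 to compound 3 (0.79 log units; beyond the scatter) in a single change. Compounds 1 and 2 alone could not show this, as they differ in more than one place. No measurement shown explains the step.

The compounds shown leave open whether the step follows the amine nitrogen or the pyrazole ring. A 1-methyl-1H-pyrazol-3-yl ring joined directly to the core, or a plain dimethylamino group, would separate the two.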